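Ring-nitrogen substituent exchange on the shared core

A few compounds are considered here, and "the series" means these few. Any claim that something is new, unique, unknown or untested is made for them only; others in the source may bear on it.

Compound 1 `NC(=O)c1c(NC(=O)c2ccccc2Cl)sc2c1CCN(Cc1ccccc1F)C2` gives 12900 nM in a functional assay on MKN-74 cells (Homo sapiens) for antiproliferative activity, with a stated time of 24 h (on this read-out lower numbers stand for stronger inhibition and higher numbers for weaker inhibition), the second highest of the three numbers. Compound 3 `NC(=O)c1c(NC(=O)c2ccccc2F)sc2c1CCN(Cc1ccc(Cl)cc1Cl)C2` gives 9610 nM, within the scatter of compound 1. Compound 2 `NC(=O)c1c(NC(=O)c2ccc(C(F)(F)F)cc2)sc2c1CCN(Cc1ccccc1F)C2` gives 26900 nM, and a 2.1-fold higher number from compound 1 to compound 2 (0.32 log units; beyond the scatter). Compound 4 `NC(=O)c1c(NC(=O)c2ccccc2Cl)sc2c1CCN(C(=O)Nc1ccccc1Cl)C2` differs from compound 1 by (2-chlorophenyl)carbamoyl in place of 2-fluorobenzyl on an amine nitrogen in a ring. Among the compounds with values here, the one measured step concerns the group on the carbonyl carbon, not the amine nitrogen in the ring, and compound 3 differs from compound 1 at two places, so no measured step bears on this change directly. With no guide to direction, a step within the scatter is expected, so a 1.0-fold higher number from compound 1 to compound 4 (0.00 log units; within the scatter) is the estimate. Compound 4 is expected to give 13000 nM in this assay, in the range 4000 nM to 40000 nM.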

Compound 4, half-maximal inhibitory concentration: 16300 nM
The estimate for compound 4 lay 1.3-fold (0.10 log units) below the measured number, within the range that was stated.
By their numbers in this assay, from the lowest: compounds 3, 1, 4 and 2 (each within the scatter of the next, the first and the last beyond it).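

On an amine nitrogen in a ring, (2-chlorophenyl)carbamoyl in place of 2-fluorobenzyl gives a 1.3-fold higher number from compound 1 to compound 4 (0.10 log units; within the scatter) in this assay. Within the data shown here, this is the only measured single change at this position, and the read-out stays within the scatter although the entering group brings a hydrogen-bond donor and a double bond outside aromatic rings. No supporting data bear on why the number stays there.

Open, as far as these compounds go, is whether a group without an aromatic ring on this nitrogen, such as a longer alkyl chain ending in an amine or a carboxylic acid, would hold the number. Also open, from the compounds shown here alone, is whether the same exchange gives a similar step with another group on the carbonyl carbon.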